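This account rests on a few compounds, and the source may have more. Where it says the series, first, only, none or still open, it means among the compounds named here.

Measured compounds:
compound 1 `CCOC(=O)c1sc(-c2ccccc2)nc1N1CCC(NCc2ccccc2)CC1` — 11.7%
compound 2 `CCOC(=O)c1sc(-c2ccccc2)nc1N1CCC(NCc2ccc(OC)cc2)CC1` — 8.4%
compound 3 `CCOC(=O)c1sc(-c2ccccc2)nc1N1CCC(NCc2ccc(OCc3ccccc3)cc2)CC1` — 18.4%

In an ADME assay on RAW264.7 cells (Mus musculus) for cytotoxicity, read by MTT assay, with a stated time of 72 h, tested at 50 uM (on this read-out higher numbers stand for more inhibition at the one concentration tested (going by the name of the read-out) and lower numbers for less inhibition), compound 1 stands second highest of the three numbers. Its nearest neighbour is compound 2, with a number 3.3 percentage points lower from compound 1 to compound 2 (within the scatter); its furthest is compound 3, with a number 6.7 percentage points higher from compound 1 to compound 3 (within the scatter). Compound 4 `CCOC(=O)c1sc(-c2ccccn2)nc1N1CCC(NCc2ccccc2)CC1` differs from compound 1 by pyridin-2-yl in place of phenyl on an aromatic carbon. Among the measured compounds shown here, no measured step touches this place: the steps seen, a number 3.3 percentage points lower from compound 1 to compound 2 (within the scatter), a number 6.7 percentage points higher from compound 1 to compound 3 (within the scatter) and a number 10 percentage points higher from compound 2 to compound 3 (within the scatter), all alter the benzyl end and all stay within the scatter. For the measured compounds named here, with no step bearing directly on this change, and no change of the benzyl end shifting the read-out beyond the scatter, no step beyond the scatter is expected for compound 4 either. Compound 4 is therefore estimated at 12%, ranging from 2% to 24%. This estimate means an expected step of a number 0.3 percentage points higher from compound 1 to compound 4 (within the scatter).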

Compound 4, a percentage reported as inhibition, at one concentration (the size of the read-out at that concentration, not a potency): 14.6%
For compound 4 the middle estimate is 2.6 percentage points below the measured one, and the stated range covers the measured number.
By their numbers in this assay, from the lowest: compounds 2, 1, 4 and 3 (each within the scatter of the next).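

In this assay, pyridin-2-yl in place of phenyl on the aromatic carbon next to the ring nitrogen and next to the ring sulfur gives a number 2.9 percentage points higher from compound 1 to compound 4 (within the scatter). With a ring nitrogen and a hydrogen-bond acceptor entering at this place, away from the benzyl end, the number thus stays level, without a step beyond the scatter. No evidence is available that would explain this result. Still open, from the compounds shown here alone, is whether an amine or a carboxylic acid at this place would move the number beyond the scatter.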